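The source may report more compounds than this note shows. Statements on the series, on what has been measured and on what is new or still open speak of the compounds shown alone.

Measured compounds:
compound 1, `CCOC(=O)NC(=O)NC1=CS(=O)(=O)O[C@@]12[C@@H](CO[Si](C)(C)C(C)(C)C)O[C@@H](n1cc(C)c(=O)n(C)c1=O)[C@@H]2O[Si](C)(C)C(C)(C)C`, 14000 nM;
compound 2, `COC(=O)C(=O)CNC1=CS(=O)(=O)O[C@@]12[C@@H](CO[Si](C)(C)C(C)(C)C)O[C@@H](n1cc(C)c(=O)n(C)c1=O)[C@@H]2O[Si](C)(C)C(C)(C)C`, > 200000 nM;
compound 3, `Cc1cn([C@@H]2O[C@H](CO[Si](C)(C)C(C)(C)C)[C@@]3(OS(=O)(=O)C=C3NCCC(=O)O)[C@H]2O[Si](C)(C)C(C)(C)C)c(=O)n(C)c1=O`, 34000 nM.

In a functional assay on HEL cells (Homo sapiens) (a higher number here means that more compound is tolerated, a lower number that less compound is tolerated), compound 1 gives the lower of the two numbers shown. Compound 3 lies above it, a 2.4-fold higher number from compound 1 to compound 3 (0.39 log units; beyond the scatter). For compound 2 the assay reports only a limit, (the limit of > 200000 nM in this assay, at which 1 of the 3 values shown sits). That limit also sets the change from compound 1, an at least 14-fold higher number from compound 1 to compound 2 (1.15 log units; beyond the scatter), and between compound 2 and compound 3 the step reads an at least 5.8-fold lower number from compound 2 to compound 3 (0.76 log units; beyond the scatter).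

Compound 4, `CCNC(=O)NC1=CS(=O)(=O)O[C@@]12[C@@H](CO[Si](C)(C)C(C)(C)C)O[C@@H](n1cc(C)c(=O)n(C)c1=O)[C@@H]2O[Si](C)(C)C(C)(C)C`, differs from compound 1 in one place: ethyl in place of ethoxycarbonyl on an amide-type nitrogen. Within the data shown here, no measured step removes the ethoxycarbonyl from the carbamoyl nitrogen while keeping the urea. The two steps that bear on it both rework the substituent on the same amine nitrogen of the shared core, and both raise the number in this assay: modestly when the whole group becomes 2-carboxyethyl, and at least strongly when it becomes ((methoxycarbonyl)carbonyl)methyl. Compound 4 keeps more of compound 1 than either, so a modest rise, if any, is expected, a 1.8-fold higher number from compound 1 to compound 4 (0.25 log units; within the scatter). Compound 4 is therefore estimated at 25000 nM, with a range from 8000 nM to 80000 nM.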

Compound 4, half-maximal cytotoxic concentration: 10000 nM
Beside the measured number, compound 4's estimate is 2.5-fold (0.40 log units) above it; the range from low to high includes it.
By their numbers in this assay, from the lowest: compounds 4 and 1 (each within the scatter of the next); then compound 3. At a limit, above all of these: compound 2.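

Ethyl in place of ethoxycarbonyl on an amide-type nitrogen gives a step that lies within the scatter in this assay (a 1.4-fold lower number from compound 1 to compound 4 (0.15 log units; within the scatter)), so the ethoxycarbonyl, with its carbonyl and its two oxygens, is not required for the number seen with compound 1. The ethylcarbamoyl group thus also separates from the other substituents on the amine nitrogen of the shared core, by a modest step from the 2-carboxyethyl group (a 3.4-fold lower number from compound 3 to compound 4 (0.53 log units; beyond the scatter)) and by a large one from the ((methoxycarbonyl)carbonyl)methyl group (an at least 20-fold lower number from compound 2 to compound 4 (1.30 log units; beyond the scatter)). The second of these steps rests on a limit of the assay for compound 2, not on a number.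

The compounds shown leave open how a longer chain, a phenyl ring or a terminal amine in place of the ethyl would read in this assay. They also leave open whether a bare carbamoyl group on that amine nitrogen would stay with compound 1 and compound 4.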